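The compounds below may be only part of what the source reports. "The series", "measured", "known", "first", "only" and "open" are said of these compounds alone.

Measured so far:
compound 1, `O=C(CCc1ccccc1)Nc1nc2ccccc2c(=O)s1`, gives 17.6 nM in an in vitro assay on cells for inhibition of Amine oxidase [flavin-containing] B (Homo sapiens), read by fluorescence and Amplex Red, with stated times of 30 min and 45 min; a higher number here means a weaker inhibitor, a lower number a stronger inhibitor;
compound 2, `Cc1sc2nc(NC(=O)CCCc3ccccc3)sc(=O)c2c1C`, gives 9.8 nM in this assay;
compound 3, `COc1cccc(/C=C/CC(=O)Nc2nc3ccccc3c(=O)s2)c1`, gives 238 nM in this assay.

Compound 1 stands second highest of these three numbers. Compound 2 sits close to it, within the usual scatter, while compound 3 sits far above it, beyond the scatter. Compound 4, `O=C(CCCc1cccc(Cl)c1)Nc1nc2ccccc2c(=O)s1`, has not yet been measured. It differs from compound 1 by 3-chlorobenzyl in place of phenyl on a saturated chain carbon, two bonds along the chain from a carbonyl carbon. Going by the values given here, no measured pair shows this exact change, so the size of the step is open. Compound 2, with its own longer chain, gives 9.8 nM and suggests a step near or within the scatter. Compound 4 is therefore expected to give 12 nM, with a range from 4 nM to 40 nM, a step of a 1.5-fold lower number from compound 1 to compound 4 (0.17 log units; within the scatter) that is expected to be small.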

Compound 4, half-maximal inhibitory concentration: > 1000 nM
Compound 4: a limit, no number (the forecaster's own chance of this, stated with the estimate: 2%); middle value at least 83-fold (1.92 log units) from the limit.
By their numbers in this assay, from the lowest: compounds 2 and 1 (each within the scatter of the next); then compound 3. At a limit, above all of these: compound 4.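

The first step read at this position is large: 3-chlorobenzyl in place of phenyl gives an at least 56-fold higher number from compound 1 to compound 4 (1.75 log units; beyond the scatter). The earlier compounds shown here showed no such step, and this one shows that a change at this place on the chain can cost far more than the scatter. On these data alone, compound 4 has only a limit, not a number, so the true size of the step stays unknown: the limit of > 1000 nM in this assay, at which 1 of the 4 values shown sits. The change adds both chlorine and chain length, and this single step cannot separate them. Plain benzyl or 3-chlorophenyl on the core of compound 1 would do so.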